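The source may report more compounds than this note shows. Statements on the series, on what has been measured and on what is new or still open speak of the compounds shown alone.

Compound 2 `CCOC(=O)[C@@H]1CCCN(S(=O)(=O)c2ccc(S(=O)(=O)N3CCCCC3)cc2)C1` carries an ethyl ester on its core and two sulfonyl groups, the outer one bearing piperidin-1-yl. In a functional assay on MIA PaCa-2 cells (Homo sapiens) for inhibition, read by MTT assay, with a stated time of 3 days (on this read-out higher numbers stand for weaker inhibition and lower numbers for stronger inhibition), compound 2 gives > 10000 nM, which is a limit of the assay and not a number. Compound 1 `CCCN(CCC)S(=O)(=O)c1ccc(S(=O)(=O)N2CCC[C@@H](C(=O)OCC)C2)cc1` is in the same position: in this assay compound 1 gives > 10000 nM, again only a limit. Compound 3 `CCOC(=O)[C@@H]1CCCN(C(=O)c2ccc(S(=O)(=O)N(CC)CC)cc2)C1` likewise gives in this assay > 10000 nM, once more a limit. All three values therefore sit at the limit of > 10000 nM in this assay, at which 3 of the 3 values shown sit. Among the compounds with values here, the single step between measured neighbours, a step that the two limits leave unreadable from compound 1 to compound 2, cannot be read: neither its size nor its direction is visible behind the two limits. Compound 4 `CCOC(=O)[C@@H]1CCCN(S(=O)(=O)c2ccc(S(=O)(=O)N(CC)C(C)C)cc2)C1` differs from compound 2 by ethyl(isopropyl)amino in place of piperidin-1-yl on a sulfonyl sulfur. Within the data shown here, no measured step speaks readably to this change; the one step that touches the same sulfonyl sulfur, from compound 1 to compound 2, exchanged one amine for another and stayed hidden. With nothing to read, no step beyond the scatter is expected in this assay in either direction. For compound 4 a step that the limit leaves unreadable from compound 2 to compound 4 is expected. Compound 4 is expected to give 15000 nM in this assay, between 4000 nM and 60000 nM, most probably reported once more only as a limit.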

Compound 4, half-maximal inhibitory concentration: > 10000 nM
Compound 4 was reported as a limit; the forecaster's own chance of this, stated with the estimate: 85%; the middle value is on the limit's open side.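

Compound 4 is reported only as a limit, as are compound 1 and compound 2, so the steps from compound 2 and from compound 1 to compound 4 cannot be read: the limit of > 10000 nM in this assay, at which 4 of the 4 values shown sit.

The compounds shown leave open whether piperidin-1-yl, ethyl(isopropyl)amino and dipropylamino on a sulfonyl sulfur differ at all in this assay, and what actual value any of these compounds has.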